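Hydroxyphenyl versus fluorophenyl substituents on the shared core

The source may report more compounds than this note shows. Statements on the series, on what has been measured and on what is new or still open speak of the compounds shown alone.

The series rests on a shared core carrying a varied aryl group on an aromatic carbon. Compound 1 `CCC1=C(O)c2c(oc(-c3ccc(O)cc3)cc2=O)C(CC)(CC)C1=O` bears a 4-hydroxyphenyl group and in a functional assay on KBVIN cells (Homo sapiens) for antiproliferative activity, read by sulforhodamine B assay, with a stated time of 3 days (a higher number here means that more compound is needed for the effect, a lower number that less compound is needed), compound 1 gives 20.6 uM. Going by the values given here, compound 2 `CCC1=C(O)c2c(oc(-c3ccccc3F)cc2=O)C(CC)(CC)C1=O` bears a 2-fluorophenyl group, and in this assay compound 2 gives 3.93 uM, the lowest of the two numbers so far; the only measured step is a 5.2-fold lower number from compound 1 to compound 2 (0.72 log units; beyond the scatter).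

Compound 3 `CCC1=C(O)c2c(oc(-c3cc(C)c(O)c(C)c3)cc2=O)C(CC)(CC)C1=O` is not yet measured. Relative to compound 2 the change is 4-hydroxy-3,5-dimethylphenyl in place of 2-fluorophenyl on an aromatic carbon. Among the compounds with values here, the one measured step bears on it in reverse: it returns a hydroxyl to the aryl group, as in compound 1, with two methyl groups added. Within the data shown here, the step from compound 1 to compound 2 is the only guide, and it is a modest one. Among the measured compounds shown here, a number above that of compound 2 is therefore expected, likely between the values of compound 1 and compound 2, since the added methyl groups have no precedent. For compound 3 the expected step is a 2.5-fold higher number from compound 2 to compound 3 (0.41 log units; beyond the scatter). Compound 3 is estimated at 10 uM, with a range from 3 uM to 30 uM.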

Compound 3, concentration for half-maximal effect: 8.9 uM
Beside the measured number, compound 3's estimate is 1.1-fold (0.05 log units) above it; the measured number falls inside the stated range.
By their numbers in this assay, from the lowest: compound 2; then compound 3; then compound 1.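

At this aromatic carbon next to the ring oxygen, a hydroxyl on the aryl group no longer marks only the high end of the series in this assay. With the two methyl groups added to the hydroxyphenyl group, the change gives a 2.3-fold lower number from compound 1 to compound 3 (0.36 log units; beyond the scatter), so the number at this position responds to substitution on the hydroxyphenyl group and not only to the swap between hydroxyl and fluorine. The 2-fluorophenyl group still holds the lowest number, with a 2.3-fold higher number from compound 2 to compound 3 (0.35 log units; beyond the scatter), which places compound 3 between compound 2 and compound 1, and no measurement is at hand that would explain either step.

The compounds shown leave open whether the low number of compound 2 belongs to the fluorine itself or to where it sits on the aryl group, which a 4-fluorophenyl group would test, and whether a single methyl group would do what the pair does in compound 3. As far as these compounds go, how an amine or a carboxylic acid on the aryl group would read at this position also remains open.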